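Phenylsulfonyl in Place of Pyrrolyl on a Weakly Active Core

The compounds below may be only part of what the source reports. "The series", "measured", "known", "first", "only" and "open" are said of these compounds alone.

Compound 1 `COc1cc(OC)c2c(=O)cc(C(=O)Nc3ccc(C4CCCCC4)cc3)[nH]c2c1` gives 36200 nM in an ADME assay on BJ cells (Homo sapiens) for antiproliferative activity, with a stated time of 72 h; a lower number here means that less compound is needed, a higher number that more compound is needed for the effect.
Compound 2 `COc1cc(OC)c2c(=O)cc(C(=O)Nc3ccc(Oc4cccnc4)cc3)[nH]c2c1` gives only a limit, > 32100 nM, in this assay.
Compound 3 `COc1cc(OC)c2c(=O)cc(C(=O)Nc3ccc(-n4cccc4)cc3)[nH]c2c1` also gives only a limit, > 77000 nM, in this assay.

The three compounds share one core and differ only in the group on an aromatic carbon. Compound 3 stands as a limit (the limit of > 77000 nM in this assay, at which 1 of the 3 values shown sits), and one further value is a limit as well (the limit of > 32100 nM in this assay, at which 1 of the 3 values shown sits). Compound 4 `COc1cc(OC)c2c(=O)cc(C(=O)Nc3ccc(S(=O)(=O)c4ccccc4)cc3)[nH]c2c1` carries phenylsulfonyl in place of 1H-pyrrol-1-yl on an aromatic carbon. Of the measured steps, an at least 2.1-fold higher number from compound 1 to compound 3 (0.32 log units; beyond the scatter) raised the number, while a step that the limit leaves unreadable from compound 1 to compound 2 and a step that the two limits leave unreadable from compound 2 to compound 3 cannot be read. Within the data shown here, every change at this position so far has left the compounds weak in this assay, so compound 4 is expected to remain weak, with the step of an at least 1.7-fold lower number from compound 3 to compound 4 (0.23 log units; that floor lies within the scatter) expected to stay within the scatter. Compound 4 is therefore estimated at 45000 nM, between 15000 nM and 120000 nM.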

Compound 4, half-maximal effective concentration: > 70600 nM
Compound 4: no number, only a limit (the forecaster's own chance of this, stated with the estimate: 45%); middle value at least 1.5-fold (0.19 log units) away from the limit.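

With phenylsulfonyl at this position, compound 4 is a third compound in this assay that gives a limit and not a number. Against cyclohexyl, the only group here with a number, phenylsulfonyl gives an at least 1.9-fold higher number from compound 1 to compound 4 (0.29 log units; that floor lies within the scatter), so this step alone does not establish a real difference. The steps to compound 4 from compound 2 and from compound 3 cannot be read. Still open, on these data alone, are the actual numbers of compound 2, compound 3 and compound 4, and whether an amine or a carboxylic acid at this position would give a lower number in this assay.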